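Dihydroindole to Tetrahydroquinolinylmethyl on a Shared Core

A few compounds are considered here, and "the series" means these few. Any claim that something is new, unique, unknown or untested is made for them only; others in the source may bear on it.

The account follows a series built on one shared core. Compound 1, `COc1ccc2[nH]c(C(=O)N3CC(=O)N(Cc4ccccc4)[C@@H](N4CCc5ccccc54)C3)cc2c1`, is the point of departure; in a physicochemical assay for solubility, read by spectrophotometry, in phosphate buffer, with a stated time of 2 h, at pH 7.4 (on this read-out higher numbers stand for higher solubility and lower numbers for lower solubility), compound 1 gives 7000 nM. Compound 2, `COc1ccc2[nH]c(C(=O)N3CC(=O)N(Cc4ccccc4)[C@@H](CN4CCN(Cc5ccccn5)CC4)C3)cc2c1`, carries a (pyridin-2-ylmethyl)piperazinylmethyl arm, and in this assay compound 2 reaches only a limit of the assay, > 100000 nM, which is the limit of > 100000 nM in this assay, at which 1 of the 2 values shown sits. Among the compounds with values here, compound 1 therefore stands as the only numerical value in the set, with the other result being a limit rather than a number.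

Compound 3, `COc1ccc2[nH]c(C(=O)N3CC(=O)N(Cc4ccccc4)[C@@H](CN4CCCc5ccccc54)C3)cc2c1`, has not yet been measured. It differs from compound 1 in a single place: (1,2,3,4-tetrahydroquinolin-1-yl)methyl in place of 2,3-dihydro-1H-indol-1-yl on a saturated ring carbon. Within the data shown here, no measured pair in the set shows this change, so the size of the step in this assay has to be estimated rather than read. The expectation is that the step of a 1.8-fold lower number from compound 1 to compound 3 (0.24 log units; within the scatter) will be modest, most likely within or just beyond the usual scatter, with a lean toward lower solubility. For compound 3 the estimated solubility in this assay is 4000 nM, with a range from 1200 nM to 15000 nM.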

Compound 3, solubility: 8500 nM
Estimate against measurement, compound 3: 2.1-fold (0.33 log units) below; low and high end bracket the measured number.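

In this assay, setting (1,2,3,4-tetrahydroquinolin-1-yl)methyl in place of 2,3-dihydro-1H-indol-1-yl on a saturated ring carbon gives a 1.2-fold higher number from compound 1 to compound 3 (0.08 log units; within the scatter) and so leaves the reading of this pair unchanged within the usual scatter. Within the data shown here, this is the first step at this position that can be read as a number, and it shows that the read-out tolerates this exchange of one group for another with the same counts of hydrogen-bond donors and acceptors, no net charge and a six-membered aromatic ring of carbon only. Compound 2 remains a limit of the assay and not a number, so no step to it can be read: the limit of > 100000 nM in this assay, at which 1 of the 3 values shown sits.

The single step changes the ring size and adds a methylene link together, so the compounds shown leave open what each change does alone, which (2,3-dihydro-1H-indol-1-yl)methyl or 1,2,3,4-tetrahydroquinolin-1-yl on the same carbon could separate. They also leave open how a group of another kind at this carbon, such as a carboxylic acid or a primary amine on a short chain, would read in this assay on the shared core.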